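A few compounds are considered here, and "the series" means these few. Any claim that something is new, unique, unknown or untested is made for them only; others in the source may bear on it.

Measured so far:
Compound 1, `C(=C/c1nn2c(-c3ccncc3)nnc2s1)\c1ccco1`: in an assay for binding affinity to histone-lysine N-methyltransferase, H3 lysine-79 specific (Homo sapiens), read by surface plasmon resonance (a higher number here means weaker binding, a lower number tighter binding), compound 1 gives 7400 nM.
Compound 2, `COc1ccccc1-c1nnc2sc(/C=C/c3ccco3)nn12`: in this assay compound 2 gives 7080 nM.

Compound 1 has the higher of the two numbers, but compound 2 sits so close that the two values cannot be separated within the usual scatter of repeated measurements, so neither can be called the tighter binder. Both are weak binders on this scale.

Compound 3, `Cc1cccc(-c2nnc3sc(/C=C/c4ccco4)nn23)c1`, has not yet been measured. It is made from compound 1 by one change: 3-methylphenyl in place of pyridin-4-yl on an aromatic carbon. Within the data shown here, no measured pair shows what this kind of change does. Among the measured compounds shown here, the only guide is that compound 1 and compound 2, which differ at this same point, give nearly the same number, and that hints that swapping the aromatic group here moves the result little. The expected step is a 1.1-fold lower number from compound 1 to compound 3 (0.06 log units; within the scatter), small enough to lie within the scatter. For compound 3 in this assay the estimate is 6500 nM, with a likely range from 2500 nM to 17000 nM.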

Compound 3, dissociation constant: 1210 nM
For compound 3 the middle estimate is 5.4-fold (0.73 log units) above the measured one; the measured number lies below the stated range.
By their numbers in this assay, from the lowest: compound 3; then compounds 2 and 1 (each within the scatter of the next).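

In this assay the group at this position can matter after all: a 6.1-fold lower number from compound 1 to compound 3 (0.79 log units; beyond the scatter) shows that the close numbers of compound 1 and compound 2 do not hold for every aromatic group placed here. The change swaps pyridin-4-yl, whose ring holds a nitrogen, for 3-methylphenyl, whose ring is carbon only and carries a methyl, so this one pair cannot separate the effect of losing that ring nitrogen from the effect of adding the methyl. No measurement shown gives a reason for the step.

An unsubstituted phenyl would help to pull those two parts apart. Going by these compounds, it also remains open whether a larger group at the 3-position of the phenyl ring, such as ethyl or chloro, would follow the same direction.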